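Replacing the 2-methyl-1H-imidazol-1-yl group of compound 2

The compounds below may be only part of what the source reports. "The series", "measured", "known", "first", "only" and "open" are said of these compounds alone.

In an ADME assay on microsomes from liver (Homo sapiens) for metabolic stability, read by LC-MS, using NADPH, with stated times of 5 min and 30 min, tested at 1 uM (a lower number here means slower removal, a higher number faster removal of the compound), compound 2 (`Cc1nccn1-c1cnc(NCc2c(F)ccc3c2CCO3)c2cn[nH]c(=O)c12`) gives 8 mL.min-1.g-1. Compound 1 (`CN(c1ncco1)c1cnc(NCc2c(F)ccc3c2CCO3)n2cnnc12`) gives 11 mL.min-1.g-1, and compound 3 (`CN(C)Cc1ccc(C(=O)Nc2cnc(NCc3c(F)ccc4c3CCO4)n3cnnc23)cc1`) gives 13 mL.min-1.g-1. All three numbers lie within the scatter of one another, so compound 2 stands level with the other two on this read-out.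

Compound 4 (`Cc1nc(CN(C)C)ccc1-c1cnc(NCc2c(F)ccc3c2CCO3)c2cn[nH]c(=O)c12`) carries 6-((dimethylamino)methyl)-2-methylpyridin-3-yl in place of 2-methyl-1H-imidazol-1-yl on an aromatic carbon. For the measured compounds named here, no measured pair of compounds differs in one place, so the size of this change has no direct precedent here. The nearest guide is compound 3, which also bears a dimethylamino-ending side chain and gives 13 mL.min-1.g-1 in this assay. A small upward move is therefore expected, and the estimated step, a 1.5-fold higher number from compound 2 to compound 4 (0.18 log units; within the scatter), stays within the scatter. For compound 4 the estimated value is 12 mL.min-1.g-1, with an expected range of 6 mL.min-1.g-1 to 25 mL.min-1.g-1.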

Compound 4, intrinsic clearance in microsomes: 13 mL.min-1.g-1
For compound 4 the middle estimate is 1.1-fold (0.03 log units) below the measured one; low and high end bracket the measured number.
By their numbers in this assay, from the lowest: compounds 2, 1, 3 and 4 (each within the scatter of the next).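

For the compounds shown here, this is the first step between compounds that differ in one place, and it shows that 6-((dimethylamino)methyl)-2-methylpyridin-3-yl in place of 2-methyl-1H-imidazol-1-yl gives a 1.6-fold higher number from compound 2 to compound 4 (0.21 log units; within the scatter) in this assay. At this aromatic carbon, the six-membered aromatic ring with its dimethylamino-ending side chain therefore leaves compound 4 level with compound 2, although the entering group is the larger of the two. Nothing measured here accounts for this result.

The compounds shown leave open whether a plain 2-methylpyridin-3-yl group, without the side chain, would also stay level with compound 2. They also leave open whether a morpholine or a carboxylic acid at the end of that chain would move the number beyond the scatter.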